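The compounds below may be only part of what the source reports. "The series", "measured", "known", "first", "only" and "open" are said of these compounds alone.

Series notes. Compound 3 `CCn1c(CN2CCN(C(=O)C3CC3)CC2)nc2ccccc21` stands lowest of the three measured compounds in an assay on isolated protein for inhibition of aldehyde dehydrogenase 1A1 (Homo sapiens), read by spectrophotometry, tested at 10 uM (on this read-out higher numbers stand for more inhibition at the one concentration tested (going by the name of the read-out) and lower numbers for less inhibition), giving 20.8%; compound 1 `CC(C)=CCn1c(CN2CCN(C(=O)C3CC3)CC2)nc2ccccc21` gives 74.3% and compound 2 `CC(C)CCn1c(CN2CCN(C(=O)C3CC3)CC2)nc2ccccc21` gives 70%. Compound 4 `O=C(C1CC1)N1CCN(Cc2nc3ccccc3n2Cc2cccc(Cl)c2)CC1` differs from compound 3 by 3-chlorophenyl in place of methyl on a saturated chain carbon bound to an aromatic nitrogen. Within the data shown here, the steps that bear on this site are a number 53.5 percentage points lower from compound 1 to compound 3 (beyond the scatter) and a number 49.2 percentage points lower from compound 2 to compound 3 (beyond the scatter), both large, whereas a number 4.3 percentage points lower from compound 1 to compound 2 (within the scatter) is within the scatter, so among the measured compounds a larger group on that carbon went with a much higher read-out, whichever of the two larger groups was present. A large upward step is therefore expected, a number 47.2 percentage points higher from compound 3 to compound 4 (beyond the scatter) in this assay. Compound 4 is estimated at 68% with a range of 45% to 88%.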

Compound 4, a percentage reported as inhibition, at one concentration (the size of the read-out at that concentration, not a potency): 71.6%
Beside the measured number, compound 4's estimate is 3.6 percentage points below it, and the stated range covers the measured number.
By their numbers in this assay, from the lowest: compound 3; then compounds 2, 4 and 1 (each within the scatter of the next).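

In this assay the rise on this carbon is not confined to branched chains: 3-chlorophenyl in place of methyl gives a number 50.8 percentage points higher from compound 3 to compound 4 (beyond the scatter) and so restores the read-out with an aromatic ring. Against the chains there is a number 1.6 percentage points higher from compound 2 to compound 4 (within the scatter) with isobutyl replaced and a number 2.7 percentage points lower from compound 1 to compound 4 (within the scatter) with 2-methylprop-1-en-1-yl replaced, so these three larger groups cannot be ranked. No measurement available explains this. Going by these compounds, whether the chlorine matters stays open, as an unsubstituted benzyl would show. Also open, on these data alone, is how an amine or carboxylic acid at this site would read.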